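Oxime chain swap at a uridine triphosphate core

The source may report more compounds than this note shows. Statements on the series, on what has been measured and on what is new or still open speak of the compounds shown alone.

Compound 1 `O=c1[nH]/c(=N\OCCCc2ccc(F)cc2)ccn1[C@@H]1O[C@H](COP(=O)(O)OP(=O)(O)OP(=O)(O)O)[C@@H](O)[C@H]1O`: 1210 nM
Compound 2 `O=c1[nH]/c(=N\OCCCc2ccc(Br)cc2)ccn1[C@@H]1O[C@H](COP(=O)(O)OP(=O)(O)OP(=O)(O)O)[C@@H](O)[C@H]1O`: 225 nM
Compound 3 `COc1ccc(CCCO/N=c2/ccn([C@@H]3O[C@H](COP(=O)(O)OP(=O)(O)OP(=O)(O)O)[C@@H](O)[C@H]3O)c(=O)[nH]2)cc1`: 277 nM

In a functional assay on 1321-N1 cells for agonist activity at P2Y purinoceptor 6 (Homo sapiens), read by scintillation counting and inositol phosphate accumulation (a higher number here means that more compound is needed for the effect, a lower number that less compound is needed), compound 3 gives 277 nM, the second highest of the three numbers. Its nearest neighbour is compound 2, with a 1.2-fold higher number from compound 2 to compound 3 (0.09 log units; within the scatter); its furthest is compound 1, with a 4.4-fold lower number from compound 1 to compound 3 (0.64 log units; beyond the scatter). The measured steps all exchange one group on the aromatic ring: a 5.4-fold lower number from compound 1 to compound 2 (0.73 log units; beyond the scatter) and a 4.4-fold lower number from compound 1 to compound 3 (0.64 log units; beyond the scatter) are modest, while a 1.2-fold higher number from compound 2 to compound 3 (0.09 log units; within the scatter) stays within the scatter.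

Compound 4 `C#CCCCO/N=c1/ccn([C@@H]2O[C@H](COP(=O)(O)OP(=O)(O)OP(=O)(O)O)[C@@H](O)[C@H]2O)c(=O)[nH]1` differs from compound 3 by ethynyl in place of 4-methoxyphenyl on a saturated chain carbon, three bonds along the chain from an oxygen on an unsaturated carbon. Among the measured compounds shown here, none of the measured steps bears directly on this change, since each of them keeps the aromatic ring and only alters its substituent. The data thus give no guide to the size or direction of the step, beyond showing that changes at the chain terminus can shift this assay by a modest amount. For the measured compounds named here, with no close precedent, compound 4 is expected to lose some potency, estimated at 800 nM with a range of 200 nM to 4000 nM, a step of a 2.9-fold higher number from compound 3 to compound 4 (0.46 log units; beyond the scatter).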

Compound 4, half-maximal effective concentration: 3000 nM
Compound 4: the middle estimate sits 3.8-fold (0.57 log units) below what was measured; the measured number falls inside the stated range.
By their numbers in this assay, from the lowest: compounds 2 and 3 (each within the scatter of the next); then compound 1; then compound 4.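

Among the compounds shown here, the first change to remove the aromatic ring altogether, leaving a pent-4-yn-1-yl chain, gives the highest number in this assay, with large steps of an 11-fold higher number from compound 3 to compound 4 (1.03 log units; beyond the scatter) and a 13-fold higher number from compound 2 to compound 4 (1.12 log units; beyond the scatter) and a modest one of a 2.5-fold higher number from compound 1 to compound 4 (0.39 log units; beyond the scatter), all beyond the scatter. Each of the three ring-bearing chains therefore outperforms the ethynyl-ended chain, and the size of the loss depends on the ring substituent used as the reference, with the 4-fluorophenyl compound closest to compound 4. Nothing available here explains this loss.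

On these data alone, it remains open whether the ring itself matters or only what the chain carries at its end. An unsubstituted phenyl, a shorter or longer chain ending in ethynyl, or a carboxylic acid at the chain end could help separate these possibilities.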